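The source may report more compounds than this note shows. Statements on the series, on what has been measured and on what is new or still open speak of the compounds shown alone.

Measured compounds:

compound 1 `C#CCOc1ccc(C(=O)Nc2cccc(C)n2)cc1` 19400 nM
compound 2 `CCOc1ccc(C(=O)Nc2cc(C)cc(C)n2)cc1` 17100 nM
compound 3 `C=CCOc1ccc(C(=O)Nc2ccccn2)cc1` 19300 nM

In an in vitro assay on HEK-tsA201 cells for antagonist activity at Neuronal acetylcholine receptor; alpha4/beta2 (Homo sapiens), read by fluorescence and calcium flux (on this read-out higher numbers stand for weaker inhibition and lower numbers for stronger inhibition), compound 1 gives 19400 nM, compound 2 gives 17100 nM and compound 3 gives 19300 nM. Compound 3 stands second highest of the three numbers; its nearest neighbour is compound 1 and its furthest is compound 2, and both gaps lie within the scatter of repeated measurements. On these numbers the three compounds cannot be told apart in this assay.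

Compound 4 `C=CCOc1ccc(C(=O)Nc2cccc(CC)n2)cc1` is compound 3 with ethyl in place of hydrogen on an aromatic carbon. Among the measured compounds shown here, no pair of measured compounds isolates this change, so its size is not known from a direct comparison. Compounds 1 and 2 carry methyl groups on the same ring as the shared core and their numbers in this assay sit within the scatter of compound 3, which gives no sign that a small alkyl group at such a place moves the read-out. The expected step from compound 3 to compound 4 is therefore a 1.0-fold lower number from compound 3 to compound 4 (0.01 log units; within the scatter), none beyond the scatter. For compound 4 the estimate in this assay is 19000 nM, within a range from 8000 nM to 45000 nM.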

Compound 4, half-maximal inhibitory concentration: 20500 nM
Estimate against measurement, compound 4: 1.1-fold (0.03 log units) below; low and high end bracket the measured number.
By their numbers in this assay, from the lowest: compounds 2, 3, 1 and 4 (each within the scatter of the next).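

In this assay, ethyl in place of hydrogen on an aromatic carbon, next to the ring nitrogen, gives a 1.1-fold higher number from compound 3 to compound 4 (0.03 log units; within the scatter). Among the compounds shown here, this is the first direct reading of a change at this position, and it shows that a group of 2 heavy atoms can enter here without a step beyond the scatter. The earlier compounds shown here could only hint at this. For the compounds shown here, no pair of them differed in one place. The data at hand hold nothing that speaks to the reason for this result.

As far as these compounds go, what a longer chain, an amine or a carboxylic acid would do at this same place remains open. So does whether any change at this position can move the number beyond the scatter at all.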